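A few compounds are considered here, and "the series" means these few. Any claim that something is new, unique, unknown or untested is made for them only; others in the source may bear on it.

Compound 1 `COc1ccc(-c2cn(/N=C/c3cc4ccccc4nc3Cl)c(N)n2)cc1` gives > 50000 nM in a functional assay on MDA-MB-231 cells (Homo sapiens) for cytotoxicity, read by MTT assay, with a stated time of 48 h (a higher number here means a weaker inhibitor, a lower number a stronger inhibitor), a limit of the assay rather than a number.
Compound 2 `COc1ccc(-c2cn(/N=C/c3cc4cc(C)ccc4nc3Cl)c(N)n2)cc1` gives 23600 nM in this assay.
Compound 3 `Nc1nc(-c2cccc3ccccc23)cn1/N=C/c1cc2ccccc2nc1Cl` gives > 50000 nM in this assay, again a limit rather than a number.

Among the compounds with values here, compound 2 holds the only actual number in this assay; the other two values are limits (the limit of > 50000 nM in this assay, at which 2 of the 3 values shown sit). Within the data shown here, the one measured step, an at least 2.1-fold lower number from compound 1 to compound 2 (0.32 log units; beyond the scatter), shows that adding a methyl moves a compound from the limit to a measurable number. Compound 4 `Cc1ccc2nc(Cl)c(/C=N/n3cc(-c4ccc5ccccc5c4)nc3N)cc2c1` keeps that methyl and changes the group on the shared core: naphthalen-2-yl in place of 4-methoxyphenyl on an aromatic carbon. Among the measured compounds shown here, no measured step tests this exchange directly; compound 3 carries a naphthyl group without the methyl and sits at the limit, as compound 1 does, so the naphthyl swap alone gave no visible gain there. The exchange from compound 2 to compound 4 is therefore expected to produce no step beyond the scatter, perhaps a slight weakening, a 1.5-fold higher number from compound 2 to compound 4 (0.17 log units; within the scatter). Compound 4 is estimated at 35000 nM in this assay, within 12000 nM to 100000 nM.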

Compound 4, half-maximal inhibitory concentration: 35600 nM
Estimate against measurement, compound 4: 1.0-fold (0.01 log units) below, within the range that was stated.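

In this assay, the exchange of 4-methoxyphenyl for naphthalen-2-yl at this position can now be given a size: a 1.5-fold higher number from compound 2 to compound 4 (0.18 log units; within the scatter). On the shared core with its methyl, two six-membered aromatic rings of carbon only can therefore stand here in place of one, and the one hydrogen-bond acceptor can go, with no change that stands out from the scatter. The earlier pair without the methyl, compound 1 and compound 3, could not show this, as neither gives a number, only a limit: the limit of > 50000 nM in this assay, at which 2 of the 4 values shown sit.

Still open, as far as these compounds go, is whether an amine or a carboxylic acid on the aromatic ring at this position would shift the number beyond the scatter. Also open, from the compounds shown here alone, is whether a small group such as methyl or a longer chain could replace the aromatic ring here without moving the value to the limit.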